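The compounds below may be only part of what the source reports. "The series", "measured", "known", "first", "only" and "open" are said of these compounds alone.

Series notes, anilino set on the shared core.

Three compounds carry numbers in a functional assay on ECa-109 cells (Homo sapiens) for inhibition, read by MTT assay, with a stated time of 72 h; a higher number here means a weaker inhibitor, a lower number a stronger inhibitor. Compound 1 `CC(C)c1ccc(-c2nc(SCc3cn(CC(=O)NC(=O)Nc4ccccn4)nn3)nc(Nc3ccc(Cl)cc3)c2C#N)cc1` gives 11200 nM. Compound 2 `CC(C)c1ccc(-c2nc(SCc3cn(CC(=O)NC(=O)Nc4ccccn4)nn3)nc(Nc3cccc(Cl)c3)c2C#N)cc1` gives 13300 nM. Compound 3 `COc1ccc(Nc2nc(SCc3cn(CC(=O)NC(=O)Nc4ccccn4)nn3)nc(-c3ccc(C(C)C)cc3)c2C#N)cc1` gives 5420 nM. Compound 1 stands second highest of the three numbers: the nearest is compound 2, with a 1.2-fold higher number from compound 1 to compound 2 (0.07 log units; within the scatter) (3-chlorophenyl in place of 4-chlorophenyl on a nitrogen on an aromatic ring), and the furthest is compound 3, with a 2.1-fold lower number from compound 1 to compound 3 (0.32 log units; beyond the scatter) (methoxy in place of chloro on an aromatic carbon). Between the other two, a 2.5-fold lower number from compound 2 to compound 3 (0.39 log units; beyond the scatter).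

Compound 4 `Cc1cccc(Nc2nc(SCc3cn(CC(=O)NC(=O)Nc4ccccn4)nn3)nc(-c3ccc(C(C)C)cc3)c2C#N)c1` is not yet measured. From compound 1 the change is 3-methylphenyl in place of 4-chlorophenyl on a nitrogen on an aromatic ring.

Within the data shown here, two measured steps bear on it. Moving the chloro from the 4-chlorophenyl to the 3-chlorophenyl position left the number within the scatter in the step from compound 1 to compound 2. Replacing chloro by methoxy gave only a modest lowering in the step from compound 1 to compound 3. Methyl is neither chloro nor methoxy, so the new substituent has no direct precedent here, and the change is expected to lie within the scatter or give at most a small lowering. The expected step is a 1.2-fold lower number from compound 1 to compound 4 (0.07 log units; within the scatter). Compound 4 is therefore estimated at 9500 nM, with a range of 4500 nM to 20000 nM.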

Compound 4, half-maximal inhibitory concentration: 7320 nM
Beside the measured number, compound 4's estimate is 1.3-fold (0.11 log units) above it; the range from low to high includes it.
By their numbers in this assay, from the lowest: compounds 3, 4, 1 and 2 (each within the scatter of the next, the first and the last beyond it).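

In this assay, the 3-methylphenyl group of compound 4 stays within the scatter of all three earlier anilino groups (a 1.5-fold lower number from compound 1 to compound 4 (0.18 log units; within the scatter); a 1.4-fold higher number from compound 3 to compound 4 (0.13 log units; within the scatter); a 1.8-fold lower number from compound 2 to compound 4 (0.26 log units; within the scatter)). Among these compounds, the step from the 3-chlorophenyl compound is the first here to exchange the substituent while the printed ring position stays the same, and methyl in place of chloro does not move the number beyond the scatter. Compound 3 stays beyond the scatter of both chloro compounds, but compound 4 is not separated from any of the three, so this position tolerates the new group without opening a clear gap, and no measurement is available to explain the result.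

The step between compound 3 and compound 4 changes both the substituent and its place on the ring, so the contribution of each remains unresolved. Also open is how the number would respond to a carboxylic acid, an amine or a longer chain on this phenyl ring, since the substituents shown are limited to chloro, methoxy and methyl.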